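This account rests on a few compounds, and the source may have more. Where it says the series, first, only, none or still open, it means among the compounds named here.

Compound 1 `COc1cccc2sc(NC(=O)c3ccc(C#N)cc3)nc12`, compound 2 `O=C(Nc1ccccc1)Nc1nc2ccc(F)cc2s1` and compound 3 `COc1ccc(C(=O)Nc2nc3cc(OC)ccc3s2)cc1` share one core and were run in a functional assay on MDA-MB-231 cells (Homo sapiens) for antiproliferative activity, read by sulforhodamine B assay; a higher number here means a weaker inhibitor of growth, a lower number a stronger inhibitor of growth. Compound 1 reaches only the limit of the method, > 10 ug/mL, not a number. Compound 2 likewise stops at the limit, > 10 ug/mL. Compound 3 also returns a limit, > 10 ug/mL. Within the data shown here, compound 1 therefore stands nowhere in a ranking, since (the limit of > 10 ug/mL in this assay, at which 3 of the 3 values shown sit); no step between measured compounds can be sized and no pattern can be drawn. Compound 4 `COc1cccc2sc(NC(=O)c3ccc([N+](=O)[O-])cc3)nc12`, not yet measured, differs from compound 1 by nitro in place of cyano on an aromatic carbon. Among the measured compounds shown here, no measured step bears on this change, so the step that the limit leaves unreadable from compound 1 to compound 4 is expected to stay within the scatter. Compound 4 is estimated at 15 ug/mL in this assay, between 6 ug/mL and 40 ug/mL.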

Compound 4, concentration for 50% growth inhibition: > 10 ug/mL
Compound 4 ended at the assay's limit; the forecaster's own chance of this, stated with the estimate: 75%; the middle value lies beyond the limit too.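

Among these compounds, compound 1 and compound 4 both stop at a limit of the method, and no step between them can be read. The compounds shown leave open how strongly any of them inhibits growth in this assay and which change to the shared core would give a readable value.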